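Sphingoid-type amino alcohols against colon carcinoma cells

The source may report more compounds than this note shows. Statements on the series, on what has been measured and on what is new or still open speak of the compounds shown alone.

Measured compounds:
compound 1, `CCCCCCCCC[C@@H](O)[C@H](C)N`, 17000 nM
compound 2, `CCCCCCCCC[C@@H](O)[C@@H](N)[C@@H](C)CC`, 2300 nM
compound 3, `CCCCCCCCCCCCCCC[C@@H](O)[C@H](C)N`, 700 nM

The three measured compounds were tested in a functional assay on WiDr cells (Homo sapiens) for antiproliferative activity, read by sulforhodamine B assay, with a stated time of 48 h; on this read-out lower numbers stand for stronger inhibition of growth and higher numbers for weaker inhibition of growth. Compound 1 is the simplest of them and in this assay compound 1 gives 17000 nM. Two changes to compound 1 were examined. The first is sec-butyl in place of methyl on a saturated chain carbon bound to an amine nitrogen and a saturated chain carbon; it produced a 7.4-fold lower number from compound 1 to compound 2 (0.87 log units; beyond the scatter). The second is hexyl in place of hydrogen on a saturated chain carbon, ten or more bonds along the chain from an oxygen on a saturated carbon; it produced a 24-fold lower number from compound 1 to compound 3 (1.39 log units; beyond the scatter). Compound 3 stands lowest of the three measured numbers, and compound 2 sits between compound 1 and compound 3.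

Compound 4, `CCCCCCCCCCCCCCC[C@@H](O)[C@@H](N)[C@@H](C)CC`, has not yet been measured. It carries both changes at once: relative to compound 3 the difference is sec-butyl in place of methyl on a saturated chain carbon bound to an amine nitrogen and a saturated chain carbon, which is the same change as that from compound 1 to compound 2, made on the core of compound 3 rather than on the core of compound 1. The two cores differ by hexyl in place of hydrogen on a saturated chain carbon, ten or more bonds along the chain from an oxygen on a saturated carbon.

For compound 4 in this assay, a step of about a 4.7-fold lower number from compound 3 to compound 4 (0.67 log units; beyond the scatter) is expected, resting on the step of a 7.4-fold lower number from compound 1 to compound 2 (0.87 log units; beyond the scatter), tempered somewhat since compound 3 already gives 700 nM and the two changes may not simply add. Compound 4 is therefore estimated at 150 nM, with a likely range from 50 nM to 500 nM.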

Compound 4, concentration for 50% growth inhibition: 13000 nM
The estimate for compound 4 lay 87-fold (1.94 log units) below the measured number; measured number outside the range, above it.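

Placed on the core that carries the added hexyl, the change from methyl to sec-butyl reversed its direction in this assay, giving a 19-fold higher number from compound 3 to compound 4 (1.27 log units; beyond the scatter), so the earlier step did not carry over to this core: the same change on two cores in this assay, a 7.4-fold lower number (0.87 log units; beyond the scatter) from compound 1 to compound 2 and a 19-fold higher number (1.27 log units; beyond the scatter) from compound 3 to compound 4, 140-fold (2.14 log units) apart, beyond the scatter of two such steps

The added hexyl behaved in the same way, since on the core that carries sec-butyl it gave a 5.7-fold higher number from compound 2 to compound 4 (0.75 log units; beyond the scatter) and not the lower number it gave on the core of compound 1: the same change on two cores in this assay, a 24-fold lower number (1.39 log units; beyond the scatter) from compound 1 to compound 3 and a 5.7-fold higher number (0.75 log units; beyond the scatter) from compound 2 to compound 4, 140-fold (2.14 log units) apart, beyond the scatter of two such steps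

This shows that, across these four compounds, the two changes do not add and the effect of each depends on which form of the other is present, but it rests on one pair of steps for each change and shows neither why the direction reverses nor how the changes would behave on any other core.

The compounds shown leave open at what chain length the sec-butyl step changes direction, and whether a chain of intermediate length or a longer chain would follow compound 3 or compound 1. They also leave open whether a smaller branch such as ethyl or isopropyl, or a benzyl group, in place of sec-butyl would reverse on the longer chain as sec-butyl does.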